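A few compounds are considered here, and "the series" means these few. Any claim that something is new, unique, unknown or untested is made for them only; others in the source may bear on it.

Within the data shown here, the three compounds measured so far share one core. Compound 1 `FC(F)(F)c1ccc(CSc2nc(N3CCCCC3)c3ccccc3n2)cc1` carries a piperidin-1-yl group, and in a functional assay on HGC-27 cells (Homo sapiens) for cytotoxicity, read by MTT assay, with a stated time of 72 h (a lower number here means a stronger inhibitor, a higher number a weaker inhibitor), compound 1 reaches only the limit of the assay at > 50000 nM. Compound 2 `COc1ccccc1Nc1nc(SCc2ccc(C(F)(F)F)cc2)nc2ccccc12` bears a (2-methoxyphenyl)amino group, and in this assay compound 2 likewise sits at the limit, > 50000 nM. Compound 3 `FC(F)(F)c1ccc(CSc2nc(Nc3cccc(Cl)c3)c3ccccc3n2)cc1` bears a (3-chlorophenyl)amino group, and in this assay compound 3 gives 19900 nM. Compound 2 therefore stands at the top of the numbers shown, where the limit of > 50000 nM in this assay, at which 2 of the 3 values shown sit, applies. The step that the two limits leave unreadable from compound 1 to compound 2 is unreadable, while an at least 2.5-fold lower number from compound 1 to compound 3 (0.40 log units; beyond the scatter) and an at least 2.5-fold lower number from compound 2 to compound 3 (0.40 log units; beyond the scatter) are known only as lower bounds. Compound 4 `FC(F)(F)c1ccc(CSc2nc(Nc3ccc(C(F)(F)F)cc3)c3ccccc3n2)cc1` is not yet measured; it differs from compound 2 by 4-(trifluoromethyl)phenyl in place of 2-methoxyphenyl on a nitrogen on an aromatic ring. Among the measured compounds shown here, only the step from compound 2 to compound 3 bears on this change. A modest step of an at least 1.6-fold lower number from compound 2 to compound 4 (0.22 log units; that floor lies within the scatter) in the same direction is expected. Compound 4 is estimated at 30000 nM, within 10000 nM to 80000 nM.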

Compound 4, half-maximal inhibitory concentration: 7560 nM
Estimate against measurement, compound 4: 4.0-fold (0.60 log units) above, outside the stated range (below it).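

In this assay, among these compounds, the change from 3-chlorophenyl to 4-(trifluoromethyl)phenyl gives a 2.6-fold lower number from compound 3 to compound 4 (0.42 log units; beyond the scatter), the first step at this place with a measured number at both ends. Replacing 2-methoxyphenyl or the whole piperidin-1-yl group yields only floors, an at least 6.6-fold lower number from compound 2 to compound 4 (0.82 log units; beyond the scatter) and an at least 6.6-fold lower number from compound 1 to compound 4 (0.82 log units; beyond the scatter). Those two steps stay floors since each starts from a limit of the assay: the limit of > 50000 nM in this assay, at which 2 of the 4 values shown sit.

The compounds shown leave open how a plain phenyl would read on this nitrogen. They also leave open whether a carboxylic acid or a nitrile on that phenyl would keep the lower number.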